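A few compounds are considered here, and "the series" means these few. Any claim that something is new, unique, unknown or untested is made for them only; others in the source may bear on it.

Measured so far in an ADME assay on microsomes from liver (Homo sapiens) for metabolic stability, read by LC-MS, with a stated time of 30 min, tested at 1 uM; a lower number here means slower removal, a higher number faster removal of the compound:
- compound 1 `C[C@@H](c1ccc2ncccc2c1)c1nnc2ccc(-c3cccc(C#N)c3)nn12`: 17.9 mL.min-1.g-1
- compound 2 `Nc1cnc2nnn(Cc3ccc4ncccc4c3)c2n1`: < 7.6 mL.min-1.g-1 (a limit)

Among the compounds with values here, compound 1 gives 17.9 mL.min-1.g-1, the only actual number so far, so it has no numeric value to be ranked against. Compound 2 gives < 7.6 mL.min-1.g-1, which is a limit of the assay and not a number. The picture in this assay therefore consists of a single number and a single limit: the limit of < 7.6 mL.min-1.g-1 in this assay, at which 1 of the 2 values shown sits.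

The next compound for this assay is compound 3 `COc1ccc(-c2ccc3nnc([C@@H](C)c4ccc5ncccc5c4)n3n2)cc1F`. It keeps the core of compound 1 and carries 3-fluoro-4-methoxyphenyl in place of 3-cyanophenyl on an aromatic carbon.

Within the data shown here, no measured step tests a change of this kind. The estimate therefore starts from compound 1 at 17.9 mL.min-1.g-1 and allows a wide range. A small upward move is expected, of a size not clearly beyond the usual scatter: a 1.6-fold higher number from compound 1 to compound 3 (0.19 log units; within the scatter). For compound 3 the estimated value is 28 mL.min-1.g-1, with an expected range from 13 mL.min-1.g-1 to 60 mL.min-1.g-1.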

Compound 3, intrinsic clearance in microsomes: 281 mL.min-1.g-1
Estimate against measurement, compound 3: 10-fold (1.00 log units) below, and the stated range ends below it.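

In this assay, replacing 3-cyanophenyl with 3-fluoro-4-methoxyphenyl on this aromatic carbon of the six-membered aromatic ring with 2 nitrogen gives a 16-fold higher number from compound 1 to compound 3 (1.20 log units; beyond the scatter), so this position strongly affects the read-out. The rest of the structure is unchanged and both groups contain one six-membered aromatic ring of carbon only, which confines the step to the substituents on that phenyl ring: the nitrile leaves, and the fluorine and methoxy enter. Nothing measured for this pair accounts for the size of the step.

The exchange removes one substituent and introduces two, so the contributions of the fluorine and the methoxy cannot be read apart, and neither can the contribution of losing the nitrile. Going by these compounds, the values for a 4-methoxyphenyl or a 3-fluorophenyl at this position remain open, as does the effect in this assay of replacing the aromatic group with a morpholine.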